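Replacing the aryl ether of compound 3 with a ring-bound heterocycle

The compounds below may be only part of what the source reports. "The series", "measured", "known", "first", "only" and "open" are said of these compounds alone.

Compound 1 `Cc1cc(Sc2cccc(Cl)c2)c(S(C)(=O)=O)cc1C(=O)N=C(N)N`: 37 nM
Compound 2 `Cc1cc(O)c(S(C)(=O)=O)cc1C(=O)N=C(N)N`: 220 nM
Compound 3 `Cc1cc(Oc2ccccc2Cl)c(S(C)(=O)=O)cc1C(=O)N=C(N)N`: 14 nM

In a functional assay for inhibition of sodium/hydrogen exchanger (Oryctolagus cuniculus) (a higher number here means a weaker inhibitor, a lower number a stronger inhibitor), compound 3 stands lowest of the three, as shown by a 2.6-fold lower number from compound 1 to compound 3 (0.42 log units; beyond the scatter) and by a 16-fold lower number from compound 2 to compound 3 (1.20 log units; beyond the scatter). Compound 4 `Cc1cc(-n2ccc(=O)cc2)c(S(C)(=O)=O)cc1C(=O)N=C(N)N` is not yet measured. The change is a group of 7 heavy atoms (5 carbon, 1 nitrogen, 1 oxygen; one six-membered aromatic ring with 1 hetero atom) in place of a group of 8 heavy atoms (6 carbon, 1 oxygen, 1 chlorine; one six-membered aromatic ring of carbon only), on an aromatic carbon, ortho to a methylsulfonyl group. Within the data shown here, two measured steps bear on it: a 16-fold lower number from compound 2 to compound 3 (1.20 log units; beyond the scatter) shows that an aromatic ring in this position lowers the number strongly, while a 2.6-fold lower number from compound 1 to compound 3 (0.42 log units; beyond the scatter) shows that exchanging one such ring for another moves it only modestly. Among the measured compounds shown here, no measured compound carries a ring with a hetero atom here, so the expectation for compound 4 is a modest rise, a 3.6-fold higher number from compound 3 to compound 4 (0.55 log units; beyond the scatter). Compound 4 is estimated at 50 nM, between 15 nM and 200 nM.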

Compound 4, half-maximal inhibitory concentration: 75 nM
For compound 4 the middle estimate is 1.5-fold (0.18 log units) below the measured one, within the range that was stated.
By their numbers in this assay, from the lowest: compound 3; then compound 1; then compound 4; then compound 2.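

The ring with a hetero atom still lowers the number relative to the hydroxy compound in this assay, a 2.9-fold lower number from compound 2 to compound 4 (0.47 log units; beyond the scatter), so a ring at this position need not be all carbon to give a gain. Yet it gives up ground against both carbon-only aryl compounds, a 5.4-fold higher number from compound 3 to compound 4 (0.73 log units; beyond the scatter) and a 2.0-fold higher number from compound 1 to compound 4 (0.31 log units; beyond the scatter), so the choice of ring here does matter. Nothing available explains this difference.

The compounds shown change the hetero atom, the carbonyl and the linking atom together, leaving their separate contributions open. On these data alone, how an amine or a carboxylic acid at this position would compare also remains open.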